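A few compounds are considered here, and "the series" means these few. Any claim that something is new, unique, unknown or untested is made for them only; others in the source may bear on it.

Measured in an ADME assay on microsomes from liver (Rattus norvegicus) for metabolic stability, read by LC-MS, using NADPH, at 37 degrees C; on this read-out lower numbers stand for a shorter-lived compound and higher numbers for a longer-lived compound:
- Compound 1 `Cc1oc(-c2ccc(Cl)c(Cl)c2)nc1CN1CCC(C(=O)NCCCN2C[C@H](C)C[C@H](C)C2)CC1`: > 0.5 h (a limit of the assay, not a number)
- Compound 2 `Cc1oc(-c2c(F)cccc2F)nc1CN1CCC(C(=O)NCCCN2C[C@H](C)C[C@H](C)C2)CC1`: 0.35 h
- Compound 3 `CCc1ccccc1-c1nc(CN2CCC(C(=O)NCCCN3C[C@H](C)C[C@H](C)C3)CC2)c(C)o1`: 0.283 h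

In this assay compound 3 gives 0.283 h, which lies within the scatter of compound 2 at 0.35 h. Compound 4 `Cc1ccc(-c2nc(CN3CCC(C(=O)NCCCN4C[C@H](C)C[C@H](C)C4)CC3)c(C)o2)cc1C` carries 3,4-dimethylphenyl in place of 2-ethylphenyl on an aromatic carbon. Going by the values given here, two measured steps bear on this change: an at least 1.7-fold lower number from compound 1 to compound 3 (0.24 log units; that floor lies within the scatter) and a 1.2-fold lower number from compound 2 to compound 3 (0.09 log units; within the scatter). Neither is shown to go beyond the scatter, so no step beyond it is expected in this assay. The expected change is a 1.2-fold higher number from compound 3 to compound 4 (0.09 log units; within the scatter). For compound 4 the estimated half-life is 0.35 h, with an expected range of 0.18 h to 0.7 h.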

Compound 4, half-life: > 0.5 h
Compound 4 was reported as a limit; the forecaster's own chance of this, stated with the estimate: 20%; middle value at least 1.4-fold (0.15 log units) from the limit.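

In this assay compound 4 gives > 0.5 h, a limit and not a number. With the same atoms joined differently, the change brings an at least 1.7-fold higher number from compound 3 to compound 4 (0.24 log units; that floor lies within the scatter) and an at least 1.4-fold higher number from compound 2 to compound 4 (0.15 log units; that floor lies within the scatter), so 3,4-dimethylphenyl joins 3,4-dichlorophenyl at the limit, though neither floor goes beyond the scatter. The step between compound 1 and compound 4 cannot be read, as both sit at the same limit: the limit of > 0.5 h in this assay, at which 2 of the 4 values shown sit.

Going by these compounds, how long compound 1 and compound 4 actually last remains open. So does whether a 3,4-disubstituted phenyl carrying an amine or a carboxylic acid would also reach this limit.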